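Phenyl in place of furan-3-yl: notes on the series

The source may hold more compounds than are shown below. What is called first, only, known or untested is meant among the compounds shown, and "the series" means these compounds.

In a functional assay on HCT-116 cells (Homo sapiens), read by MTT assay, with a stated time of 72 h (a higher number here means a weaker inhibitor, a lower number a stronger inhibitor), compound 1 `Cc1ncnc2c1c(-c1ccoc1)cn2[C@@H]1O[C@H](CO)[C@@H](O)[C@H]1O` gives > 20000 nM as its reading, which is a limit of the assay and not a number. Among the measured compounds shown here, compound 2 `Nc1nc2c(c(-c3ccoc3)cn2[C@@H]2O[C@H](CO)[C@@H](O)[C@H]2O)c(=O)[nH]1` gives 17600 nM as the only actual number so far. Compound 1 marks the limit of > 20000 nM in this assay, at which 1 of the 2 values shown sits, and nothing further is read from it.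

Compound 3 `Nc1nc2c(c(-c3ccccc3)cn2[C@@H]2O[C@H](CO)[C@@H](O)[C@H]2O)c(=O)[nH]1` has phenyl in place of furan-3-yl on an aromatic carbon with the rest of compound 2 unchanged. For the measured compounds named here, no measured single-change step exists to size this swap. With compound 2 at 17600 nM as the only anchor, little movement is expected in this assay and no direction is favoured. The expected change is a 1.1-fold lower number from compound 2 to compound 3 (0.04 log units; within the scatter) and it should stay within the usual scatter. The estimate for compound 3 is 16000 nM with an expected range from 6000 nM to 20000 nM in this assay.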

Compound 3, half-maximal inhibitory concentration: > 20000 nM
Compound 3: no number, only a limit; the forecaster's own chance of this, stated with the estimate: 40%; middle value at least 1.2-fold (0.09 log units) away from the limit.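

In this assay, among the compounds shown here, phenyl in place of furan-3-yl on an aromatic carbon gives an at least 1.1-fold higher number from compound 2 to compound 3 (0.05 log units; that floor lies within the scatter), the first single-change step at this position. Going by these compounds, compound 3 gives a limit and not a number, and the limit is shared: the limit of > 20000 nM in this assay, at which 2 of the 3 values shown sit. The step is therefore a floor and not a size, so it shows only that phenyl brings no lower number here, while the real distance from furan-3-yl stays unknown.

With only these two aromatic rings shown on this carbon, it remains open whether any group here can move the reading clearly beyond the scatter. On these data alone, how a non-aromatic group such as an amine, a carboxylic acid or a longer alkyl chain would read on this carbon also stays open.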